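From Hydrogen to Tert-Butyl on a Shared Core

The source may report more compounds than this note shows. Statements on the series, on what has been measured and on what is new or still open speak of the compounds shown alone.

Two measured compounds share one core and differ in a single group. Compound 1 `CC(C)n1nc(-c2cc(C3CCCCC3)on2)c2c(N)ncnc21` carries a cyclohexyl group, and in an assay on BaF3 cells for inhibition of proto-oncogene tyrosine-protein kinase receptor Ret variant V804M (Homo sapiens), read by MTT assay, with a stated time of 48 h (a lower number here means a stronger inhibitor of growth, a higher number a weaker inhibitor of growth), compound 1 gives 4730 nM. Compound 2 `CC(C)n1nc(-c2ccon2)c2c(N)ncnc21` carries a hydrogen in that place, and in this assay compound 2 gives 8940 nM, the highest of the two numbers shown, although the step of a 1.9-fold higher number from compound 1 to compound 2 (0.28 log units; within the scatter) lies within the scatter, so the two values cannot be told apart. Compound 3 `CC(C)n1nc(-c2cc(C(C)(C)C)on2)c2c(N)ncnc21` takes the next step: tert-butyl in place of hydrogen on an aromatic carbon. Among the compounds with values here, the only measured step that bears on this change is the one from compound 1 to compound 2, where exchanging cyclohexyl for hydrogen moved the number only within the scatter, so a tert-butyl group is expected to land near the value of compound 1. For compound 3 the expected step is a 1.8-fold lower number from compound 2 to compound 3 (0.25 log units; within the scatter), not beyond the scatter. Compound 3 is estimated at 5000 nM, with a range from 2500 nM to 10000 nM.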

Compound 3, concentration for 50% growth inhibition: 7310 nM
Compound 3: the middle estimate sits 1.5-fold (0.16 log units) below what was measured, and the stated range covers the measured number.
By their numbers in this assay, from the lowest: compounds 1, 3 and 2 (each within the scatter of the next).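

In this assay placing tert-butyl on this aromatic carbon gives a 1.2-fold lower number from compound 2 to compound 3 (0.09 log units; within the scatter) and exchanging cyclohexyl for tert-butyl at the same position gives a 1.5-fold higher number from compound 1 to compound 3 (0.19 log units; within the scatter) in turn. Compound 1, compound 2 and compound 3 therefore all lie within the scatter of one another, so at this position next to the ring oxygen, neither tert-butyl, which has no ring, nor cyclohexyl can be told apart from plain hydrogen. No supporting measurement is available that would explain this flat result.

The compounds shown leave open whether a different kind of group at this position, such as an amine, a carboxylic acid or a longer chain, would give a step beyond the scatter. They also leave open whether changes elsewhere on the shared core would do so.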